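Ester tail variation on a shared core: oral exposure

The source may report more compounds than this note shows. Statements on the series, on what has been measured and on what is new or still open speak of the compounds shown alone.

Two compounds that share one core and differ only in the ester tail have been measured in an ADME assay on the whole organism (plasma) for pharmacokinetics, with Rattus norvegicus as the target, at a dose of 10 mg/kg by the oral route; on this read-out higher numbers stand for higher exposure at the dose given and lower numbers for lower exposure. Compound 1 `CCOc1cc(NC(=O)C2(NC(=O)c3ccc4c(C5CCCC5)c(-c5ncc(Cl)cn5)n(C)c4c3)CCC2)ccc1/C=C/C(=O)OCCOCCOC` gives 74.4 ng.h/mL in this assay. Compound 2 `CCOc1cc(NC(=O)C2(NC(=O)c3ccc4c(C5CCCC5)c(-c5ncc(Cl)cn5)n(C)c4c3)CCC2)ccc1/C=C/C(=O)OCC(N)=O` gives 90.9 ng.h/mL in this assay. Going by the values given here, the one step between them, a 1.2-fold higher number from compound 1 to compound 2 (0.09 log units; within the scatter), shows that exchanging the tail on the ester oxygen left the exposure essentially unchanged, so compound 2 stands together with compound 1 rather than apart from it.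

Compound 3 `CCOc1cc(NC(=O)C2(NC(=O)c3ccc4c(C5CCCC5)c(-c5ncc(Cl)cn5)n(C)c4c3)CCC2)ccc1/C=C/C(=O)OCC(=O)N1CCOCC1` carries the next change in the same tail: morpholin-4-yl in place of amino on a carbonyl carbon. Among the compounds with values here, no measured step bears directly on this exchange; the only step available, a 1.2-fold higher number from compound 1 to compound 2 (0.09 log units; within the scatter), concerns the same ester region and was within the scatter. On that basis, a small step in this assay is expected, in no settled direction, and the estimate for compound 3 is 85 ng.h/mL with a range from 30 ng.h/mL to 240 ng.h/mL. The expected step, a 1.1-fold lower number from compound 2 to compound 3 (0.03 log units; within the scatter), therefore stays within the scatter.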

Compound 3, area under the concentration-time curve: "below limit of detection" (no number reported)
Compound 3: no number reported; no gap can be computed for the estimate.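

In this assay, going by these compounds alone, compound 3 is reported only as below the limit of detection, without a number, so no step from compound 2 to compound 3 can be read. No measurement shown bears on this result. The compounds shown leave open what number compound 3 would reach and how far it would stand from compound 2.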